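A few compounds are considered here, and "the series" means these few. Any claim that something is new, unique, unknown or untested is made for them only; others in the source may bear on it.

Among the compounds with values here, compound 1, whose structure is `CCC(C)(C)Cc1c[nH]c(CCc2ccc(-c3ccncc3)cc2)n1`, is the stronger of the two measured points in a functional assay on HEK293 cells for agonist activity at Bombesin receptor subtype-3 (Mus musculus), read by luminescence and calcium flux, with a stated time of 10 min; a lower number here means that less compound is needed, a higher number that more compound is needed for the effect: compound 1 gives 103 nM, and the only neighbour is compound 2, `CCC(C)(C)Cc1c[nH]c(CCc2ccc(-c3cccc(C#N)n3)cc2)n1`, which in this assay gives 115 nM. The step of a 1.1-fold higher number from compound 1 to compound 2 (0.05 log units; within the scatter) is within the scatter, so the two compounds cannot be ranked against each other on these numbers.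

Compound 3, `CCC(C)(C)Cc1c[nH]c(CCc2ccc(-n3cncn3)cc2)n1`, is the next point on this path. It differs from compound 1 at the same place on the shared core that changes from compound 1 to compound 2, namely (1H-1,2,4-triazol-1-yl in place of pyridin-4-yl on an aromatic carbon).

Within the data shown here, only one measured step bears on this change, and it is a loose guide: replacing pyridin-4-yl with 6-cyanopyridin-2-yl moved the number by a 1.1-fold higher number from compound 1 to compound 2 (0.05 log units; within the scatter), a step within the scatter. On that basis compound 3 is expected to stay close to compound 1 in this assay, with at most a modest rise, so the expected step is a 1.5-fold higher number from compound 1 to compound 3 (0.16 log units; within the scatter). Compound 3 is therefore estimated at 150 nM, in a range from 60 nM to 400 nM.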

Compound 3, half-maximal effective concentration: 121 nM
Compound 3: middle estimate off by 1.2-fold (0.09 log units), on the high side; the range from low to high includes it.
By their numbers in this assay, from the lowest: compounds 1, 2 and 3 (each within the scatter of the next).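

At the aromatic carbon para to a large group, the earlier pair had only exchanged one six-membered aromatic ring for another. Compound 3 shows that a five-membered aromatic ring with 3 hetero atoms, 1H-1,2,4-triazol-1-yl, can also replace pyridin-4-yl, with this assay giving a 1.2-fold higher number from compound 1 to compound 3 (0.07 log units; within the scatter) as the step for this change. Set against the nitrile-bearing ring, the step of a 1.1-fold higher number from compound 2 to compound 3 (0.02 log units; within the scatter) is equally small, so these three compounds cannot be ranked and, among them alone, the number at this position does not depend on which of the three aromatic rings is present, though no evidence is available here to account for that.

The compounds shown leave open whether this position would accept a group without an aromatic ring, such as an amine, a carboxylic acid or a longer alkyl chain, or whether the number would then move beyond the scatter. They also leave open how the number responds to changes elsewhere on the shared core, which stays the same in all three compounds.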